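From an Ester Amide to a Free Carboxy Chain

The source may report more compounds than this note shows. Statements on the series, on what has been measured and on what is new or still open speak of the compounds shown alone.

- compound 1 `C=CCN(C)C(=O)c1ccc(C(CC)(CC)c2ccc(OCCC(O)(CC)CC)c(C)c2)n1CC`: 1190 nM
- compound 2 `CCC(C)C(NC(=O)c1ccc(C(CC)(CC)c2ccc(OCCC(O)(CC)CC)c(C)c2)n1CC)C(=O)OC`: > 50000 nM (a limit of the assay, not a number)
- compound 3 `CCOC(=O)CN(C)C(=O)c1ccc(C(CC)(CC)c2ccc(OCCC(O)(CC)CC)c(C)c2)n1CC`: 1990 nM

In an ADME assay on L02 cells (Homo sapiens) for antiproliferative activity, read by MTT assay, with a stated time of 48 h (on this read-out lower numbers stand for stronger inhibition and higher numbers for weaker inhibition), compound 3 gives 1990 nM, and a 1.7-fold higher number from compound 1 to compound 3 (0.22 log units; within the scatter) stays within the usual scatter. Compound 4 `CCC(C)C(NC(=O)c1ccc(C(CC)(CC)c2ccc(OCCC(O)(CC)CC)c(C)c2)n1CC)C(=O)O` has (1-carboxy-2-methylbutyl)amino in place of ((ethoxycarbonyl)methyl)(methyl)amino on a carbonyl carbon.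

Compound 2 carries the same chain as an ester, and its result is a limit, > 50000 nM. The large steps of an at least 42-fold higher number from compound 1 to compound 2 (1.62 log units; beyond the scatter) and an at least 25-fold lower number from compound 2 to compound 3 (1.40 log units; beyond the scatter) both tie this chain to higher numbers in this assay. Among the measured compounds shown here, no measured compound here has the free carboxy group, so the guide is indirect. A large step is expected, a 20-fold higher number from compound 3 to compound 4 (1.30 log units; beyond the scatter). For compound 4 the estimated value is 40000 nM, with an expected range of 12000 nM to 100000 nM.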

Compound 4, half-maximal inhibitory concentration: 9990 nM
Estimate against measurement, compound 4: 4.0-fold (0.60 log units) above; the measured number lies below the stated range.
By their numbers in this assay, from the lowest: compounds 1 and 3 (each within the scatter of the next); then compound 4. At a limit, above all of these: compound 2.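

Hydrogen in place of methyl on the ester oxygen gives an at least 5.0-fold lower number from compound 2 to compound 4 (0.69 log units; beyond the scatter), a step read against a limit, so its full size is unknown. Even so, (1-carboxy-2-methylbutyl)amino on the carbonyl carbon still gives higher numbers in this assay than the other two groups, with a 5.0-fold higher number from compound 3 to compound 4 (0.70 log units; beyond the scatter) and an 8.4-fold higher number from compound 1 to compound 4 (0.92 log units; beyond the scatter). Compound 2 stands at a limit, not a number: the limit of > 50000 nM in this assay, at which 1 of the 4 values shown sits.

Because compound 4 differs from compounds 1 and 3 across the whole group, the effect of the amide hydrogen cannot be separated from that of the chain. On these data alone, whether an amine in place of the carboxy group would give a lower number stays open.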